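A few compounds are considered here, and "the series" means these few. Any claim that something is new, unique, unknown or untested is made for them only; others in the source may bear on it.

Compound 1, `COC(=O)[C@H](CCSC)NC(=O)c1ccc(OC[C@H]2COc3ccccc3O2)cc1-c1ccccc1C`, in a functional assay (HSMC cells, Homo sapiens) for antiproliferative activity, with a stated time of 72 h (a higher number here means a weaker inhibitor, a lower number a stronger inhibitor), gives 6600 nM. Compound 2, `COC(=O)[C@H](CCSC)NC(=O)c1ccc(OC[C@H]2COc3ccccc3O2)cc1-c1ccccc1OC`, differs from it by one change, (methoxy in place of methyl on an aromatic carbon), and in this assay compound 2 gives 230000 nM. That single exchange produced a 35-fold higher number from compound 1 to compound 2 (1.54 log units; beyond the scatter).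

Compound 3, `COC(=O)[C@H](CCSC)NC(=O)c1ccc(C(=O)NC[C@H]2COc3ccccc3O2)cc1-c1ccccc1C`, carries a different core; how the two cores differ is not broken down here. In this assay compound 3 gives 87000 nM, which stands between the two earlier numbers.

Compound 4, `COC(=O)[C@H](CCSC)NC(=O)c1ccc(C(=O)NC[C@H]2COc3ccccc3O2)cc1-c1ccccc1OC`, is built from compound 3 by the same change, (methoxy in place of methyl on an aromatic carbon), placed on the same kind of aromatic carbon with the same surroundings as in the first pair. Because a 35-fold higher number from compound 1 to compound 2 (1.54 log units; beyond the scatter) was large on the core of compound 1, a weakening of similar size is expected when the same exchange is made on the core of compound 3. The expected step is a 14-fold higher number from compound 3 to compound 4 (1.14 log units; beyond the scatter). For compound 4 the estimate in this assay is 1200000 nM, with a likely range from 250000 nM to 5000000 nM, and such a weak number may fall beyond what the assay can report.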

Compound 4, half-maximal inhibitory concentration: 252000 nM
For compound 4 the middle estimate is 4.8-fold (0.68 log units) above the measured one; low and high end bracket the measured number.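

Exchanging methyl for methoxy weakened the compound on the core of compound 3 as well, with a 2.9-fold higher number from compound 3 to compound 4 (0.46 log units; beyond the scatter) in this assay, so the direction of the change carried over from the core of compound 1. The size did not carry over, and the two steps differ by more than their scatter: the same change on two cores in this assay, a 35-fold higher number (1.54 log units; beyond the scatter) from compound 1 to compound 2 and a 2.9-fold higher number (0.46 log units; beyond the scatter) from compound 3 to compound 4, 12-fold (1.08 log units) apart, beyond the scatter of two such steps. These two pairs show that the effect of this exchange depends on the core that carries it, but they do not show which part of the cores accounts for the gap, and two cores are too few to predict the step on a further core in this series.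

The compounds shown carry only methyl or methoxy in this place, so it stays open how a hydroxyl group or a chlorine atom there would behave on either core. From the compounds shown here alone, it also stays open whether a longer chain, such as ethoxy in place of methoxy, would widen or narrow the gap between the two cores.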